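The compounds below may be only part of what the source reports. "The series", "measured", "known", "first", "only" and "open" are said of these compounds alone.

- compound 1 `COC(=O)NC(=O)c1ccsc1NC(=O)c1ccc(S(=O)(=O)N2CCCCCC2)cc1` gives 9.13 ug/mL
- compound 2 `CCOC(=O)NC(=O)c1ccsc1NC(=O)c1ccc(S(=O)(=O)N2CCCCC2)cc1` gives 18.6 ug/mL

Both numbers come from a toxicity assay on Vero cells (Chlorocebus sabaeus) for cytotoxicity, read by MTT assay (a lower number here means a stronger inhibitor, a higher number a weaker inhibitor), and the gap between them lies just beyond the scatter. Compound 2 stands highest of the two at 18.6 ug/mL while compound 1 is the nearest and lower at 9.13 ug/mL on the same read-out.

Compound 3 `CCOC(=O)NC(=O)c1ccsc1NC(=O)c1ccc(S(=O)(=O)N2CCCCCC2)cc1` differs from compound 2 in one place only, and that difference is azepan-1-yl in place of piperidin-1-yl on a sulfonyl sulfur with azepan-1-yl in place of piperidin-1-yl on a sulfonyl sulfur. Among the compounds with values here, no measured pair isolates this change. Compound 1 also carries azepan-1-yl but differs from compound 2 elsewhere as well, so the value of compound 1 at 9.13 ug/mL is only a weak guide to what the larger ring alone would show. The expected step of a 1.6-fold lower number from compound 2 to compound 3 (0.19 log units; within the scatter) is a modest one toward a lower number, and it is not expected to go beyond the scatter. In this assay the estimated value for compound 3 is 12 ug/mL with an expected range from 6 ug/mL to 25 ug/mL for most repeat measurements.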

Compound 3, half-maximal inhibitory concentration: 3.42 ug/mL
For compound 3 the middle estimate is 3.5-fold (0.55 log units) above the measured one; measured number outside the range, below it.
By their numbers in this assay, from the lowest: compound 3; then compound 1; then compound 2.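

In this assay the exchange of piperidin-1-yl for azepan-1-yl on a sulfonyl sulfur now stands alone as a 5.4-fold lower number from compound 2 to compound 3 (0.74 log units; beyond the scatter) and so gives this position a measured step of its own, which compound 1 and compound 2 could not give, since they differ in more than one place. Within the data shown here, the ring change is not the only step that counts here, for methyl in place of hydrogen on a saturated chain carbon bound to an oxygen next to a carbonyl group, with the azepan-1-yl kept, appears as a 2.7-fold lower number from compound 1 to compound 3 (0.43 log units; beyond the scatter) and places compound 3 lowest of the three, so both ends of the molecule move this read-out. Nothing in the material at hand accounts for either step, and no outside measurement bears on this result. On these data alone, each change has been read only once, so it remains open whether the ring step would hold in the methyl series of compound 1, or the chain step with piperidin-1-yl in place. How a pyrrolidin-1-yl or morpholin-4-yl group on the sulfonyl sulfur, or a propyl group in place of the ethyl, would read in this assay also stays unanswered.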